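The source may hold more compounds than are shown below. What is called first, only, known or untested is meant among the compounds shown, and "the series" means these compounds.

Measured in a toxicity assay on MDCK cells (Canis lupus familiaris) for cytotoxicity, read by crystal violet staining, with a stated time of 48 h; a lower number here means that less compound is tolerated, a higher number that more compound is tolerated:

- compound 1, `Cc1ccc2[nH]c(=O)c(CN(Cc3ccc(N(C)C)cc3)Cc3ccc(C(C)(C)C)cc3)cc2c1`, gives > 5000 nM, a limit of the assay
- compound 2, `Cc1ccc2[nH]c(=O)c(CN(Cc3ccc(SC(F)F)cc3)Cc3ccc(C(C)(C)C)cc3)cc2c1`, gives > 5000 nM, a limit of the assay
- compound 3, `Cc1ccc2[nH]c(=O)c(CN(Cc3ccc(C(C)(C)C)cc3)C(C)c3ccc(F)cc3)cc2c1`, gives > 33000 nM, a limit of the assay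

Compound 3 stands on the higher of the two limits reached in this assay, (the limit of > 33000 nM in this assay, at which 1 of the 3 values shown sits). The other two compounds sit at the lower limit, (the limit of > 5000 nM in this assay, at which 2 of the 3 values shown sit). All three steps between them are left unreadable by these limits: a step that the two limits leave unreadable from compound 1 to compound 2, a step that the two limits leave unreadable from compound 1 to compound 3 and a step that the two limits leave unreadable from compound 2 to compound 3. No number is therefore known for any step in the series; the only thing shown is that none of the three compounds reaches a measurable half-maximal cytotoxic concentration within the ranges tested.

Compound 4, `COc1ccc(C(C)N(Cc2ccc(C(C)(C)C)cc2)Cc2cc3cc(C)ccc3[nH]c2=O)cc1`, differs from compound 3 by methoxy in place of fluoro on an aromatic carbon. For the measured compounds named here, none of the measured steps changes this position, and none of them has a readable size, so no measured step bears on the change beyond showing that the shared core and the benzyl arms have tolerated every variation tried so far without a measurable result. The step from compound 3 to compound 4 is expected to be no larger than the scatter, a step that the limit leaves unreadable from compound 3 to compound 4. Compound 4 is estimated at 40000 nM, with a range from 15000 nM to 120000 nM, most likely again reported only as a limit.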

Compound 4, half-maximal cytotoxic concentration: > 5000 nM
Compound 4 ended at the assay's limit; the forecaster's own chance of this, stated with the estimate: 75%; the middle value is on the limit's open side.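

In this assay compound 4 gives > 5000 nM, a limit of the assay. Its steps from compound 1, compound 2 and compound 3 cannot be read, so this result yields no new step size. The compounds shown leave open where any of the four half-maximal cytotoxic concentrations lies, and whether methoxy in place of fluoro shifts that value at all.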